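Swapping an Ester Chain on a Shared Core

The source may hold more compounds than are shown below. What is called first, only, known or untested is meant among the compounds shown, and "the series" means these compounds.

Measured compounds in a functional assay on HeLa cells (Homo sapiens) for cytotoxicity, read by MTT assay; on this read-out lower numbers stand for stronger inhibition and higher numbers for weaker inhibition:
compound 1 `CC(C)=CC[C@@H](OC(=O)CCO)C1=CC(=O)c2c(O)ccc(O)c2C1=O`: 67600 nM
compound 2 `CC(C)=CC[C@@H](OC[C@H](C)O)C1=CC(=O)c2c(O)ccc(O)c2C1=O`: 40300 nM
compound 3 `CC(C)=CC[C@@H](OCC(C)O)C1=CC(=O)c2c(O)ccc(O)c2C1=O`: 24700 nM

Among these three, compound 1 gives the highest number in this assay. Its nearest neighbour is compound 2, reached by a 1.7-fold lower number from compound 1 to compound 2 (0.22 log units; within the scatter); the furthest is compound 3, reached by a 2.7-fold lower number from compound 1 to compound 3 (0.44 log units; beyond the scatter). Between the two lower numbers lies a 1.6-fold lower number from compound 2 to compound 3 (0.21 log units; within the scatter), and the only drawn difference between them is the fact that one of compounds 2 and 3 is drawn with a defined configuration and the other without, at the place where they differ.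

Compound 4 `CC(=O)OC(C)CO[C@H](CC=C(C)C)C1=CC(=O)c2c(O)ccc(O)c2C1=O` is not yet measured. It differs from compound 1 by 2-acetoxypropyl in place of (2-hydroxyethyl)carbonyl on an oxygen on a saturated carbon. The two measured steps from compound 1 both replaced the same leaving group with 2-hydroxypropyl, and both moved the number downward, one within the scatter and one modestly beyond it. Compound 4 instead carries 2-acetoxypropyl, a group with no hydrogen-bond donor, so the measured steps are only a partial guide. The expected step is a 2.1-fold lower number from compound 1 to compound 4 (0.32 log units; beyond the scatter). Compound 4 is therefore estimated at 32000 nM, with a range from 12000 nM to 80000 nM.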

Compound 4, half-maximal inhibitory concentration: 40100 nM
The estimate for compound 4 lay 1.3-fold (0.10 log units) below the measured number; low and high end bracket the measured number.
By their numbers in this assay, from the lowest: compounds 3, 4, 2 and 1 (each within the scatter of the next, the first and the last beyond it).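

Going by these compounds alone, putting acetyl in place of hydrogen on the hydroxyl oxygen of the side chain is a change the earlier compounds did not test, and in this assay it gives a 1.6-fold higher number from compound 3 to compound 4 (0.21 log units; within the scatter). Set against the compound with the defined configuration on that chain, the acetylated chain gives a 1.0-fold lower number from compound 2 to compound 4 (0.00 log units; within the scatter), so at this position a chain with no hydrogen-bond donor reads the same, within the scatter, as the hydroxyl chains. The replacement of (2-hydroxyethyl)carbonyl by 2-acetoxypropyl also stays within the scatter: a 1.7-fold lower number from compound 1 to compound 4 (0.23 log units; within the scatter). Nothing shown gives a cause for these steps.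

From the compounds shown here alone, whether an amine or a carboxylic acid at the end of this chain, or a much longer chain, would move the number beyond the scatter stays open. So does the role of configuration at the chain carbon, which is left undrawn in compound 4.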